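The source may hold more compounds than are shown below. What is called first, only, known or untested is meant among the compounds shown, and "the series" means these compounds.

Of the compounds shown here, three have so far been tested in a functional assay on CCRF-CEM cells (Homo sapiens) for inhibition, read by cell counting, with a stated time of 3 days; on this read-out higher numbers stand for weaker inhibition and lower numbers for stronger inhibition. Compound 1 `Nc1cccc(-c2cn3nc(-c4cccs4)sc3n2)c1` reaches only a limit of the assay: in this assay compound 1 gives > 250000 nM. Compound 2 `CCOc1ccc(-c2nn3cc(-c4cccc(N)c4)nc3s2)cc1` likewise ends at a limit, and in this assay compound 2 gives > 250000 nM. For the measured compounds named here, compound 3 `C=C(Br)C(=O)Nc1cccc(-c2cn3nc(-c4ccccc4)sc3n2)c1` is different: in this assay compound 3 gives 960 nM, which is the only actual number among the three. Compound 1 and compound 2 end at a limit, as the limit of > 250000 nM in this assay, at which 2 of the 3 values shown sit, records.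

Compound 4 `Nc1cccc(-c2cn3nc(-c4ccccc4)sc3n2)c1` has not yet been measured. It differs from compound 3 by hydrogen in place of (1-bromoethenyl)carbonyl on a nitrogen on an aromatic ring. Going by the values given here, no pair of measured compounds shows this change directly. However, compound 1 and compound 2 both carry an amino group at that nitrogen, just as compound 4 does, and both return only a limit in this assay, as the limit of > 250000 nM in this assay, at which 2 of the 3 values shown sit, shows. A large step towards weaker inhibition, far beyond the usual scatter, is therefore expected: a 260-fold higher number from compound 3 to compound 4 (2.42 log units; beyond the scatter). Compound 4 is accordingly estimated at 250000 nM, with a range from 25000 nM to 500000 nM, and it may well come back as a limit rather than a number.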

Compound 4, half-maximal inhibitory concentration: 33000 nM
Compound 4: middle estimate off by 7.6-fold (0.88 log units), on the high side; the measured number falls inside the stated range.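

In this assay, the change at this nitrogen can now be read directly: taking off the (1-bromoethenyl)carbonyl gives a 34-fold higher number from compound 3 to compound 4 (1.54 log units; beyond the scatter), yet the bare amino compound still returns a real number rather than a limit. The amino compounds also turn out to depend on the far end of the molecule, with phenyl in place of thiophen-2-yl giving an at least 7.5-fold lower number from compound 1 to compound 4 (0.87 log units; beyond the scatter), and hydrogen in place of ethoxy on an aromatic carbon giving an at least 7.5-fold lower number from compound 2 to compound 4 (0.87 log units; beyond the scatter). Both of these steps are minimum sizes, since each starts from a limit: the limit of > 250000 nM in this assay, at which 2 of the 4 values shown sit.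

The compounds shown leave open which part of the (1-bromoethenyl)carbonyl carries the large step, since a plain acetyl group on that nitrogen would keep the carbonyl but lose the bromine and the double bond. Going by these compounds, it also remains open whether thiophen-2-yl or ethoxy would matter as much with the (1-bromoethenyl)carbonyl in place.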